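Swapping the Amide Aryl Group: Phenyl to Pyridyl

The source may report more compounds than this note shows. Statements on the series, on what has been measured and on what is new or still open speak of the compounds shown alone.

Compound 1 `Cc1ccccc1N(C)C(=O)c1ccc(-c2ccc(O)cc2)o1`: 21 nM
Compound 2 `Cc1ccccc1N(C)C(=O)c1ccc(-c2ccccc2O)o1`: 1900 nM
Compound 3 `Cc1ccccc1N(C)C(=O)c1ccc(-c2ccc(O)cc2F)o1`: 10 nM

All three were tested in an assay on T47D cells for inhibition of 17-beta-hydroxysteroid dehydrogenase type 1 (Homo sapiens), read by HPLC, with a stated time of 24 h; a lower number here means a stronger inhibitor, a higher number a weaker inhibitor. Compound 1 stands second highest of the three numbers: its nearest neighbour is compound 3, reached by a 2.1-fold lower number from compound 1 to compound 3 (0.32 log units; beyond the scatter), and its furthest is compound 2, reached by a 90-fold higher number from compound 1 to compound 2 (1.96 log units; beyond the scatter). Compound 4 `Cc1ccncc1N(C)C(=O)c1ccc(-c2ccc(O)cc2)o1` differs from compound 1 by 4-methylpyridin-3-yl in place of 2-methylphenyl on an amide-type nitrogen. Going by the values given here, none of the measured steps touches the group on the amide nitrogen; all of them alter the hydroxyphenyl group at the other end of the shared core, so no measured step bears directly on this change. The expectation is therefore a step within the scatter, with wide uncertainty, namely a 1.4-fold higher number from compound 1 to compound 4 (0.15 log units; within the scatter). Compound 4 is estimated at 30 nM in this assay, with a range of 8 nM to 120 nM.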

Compound 4, half-maximal inhibitory concentration: 64 nM
Estimate against measurement, compound 4: 2.1-fold (0.33 log units) below; the range from low to high includes it.
By their numbers in this assay, from the lowest: compound 3; then compound 1; then compound 4; then compound 2.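

The group on the amide nitrogen does matter: 4-methylpyridin-3-yl in place of 2-methylphenyl gives a 3.0-fold higher number from compound 1 to compound 4 (0.48 log units; beyond the scatter) and leaves a weaker inhibitor. The swap keeps the heavy-atom count and adds one hydrogen-bond acceptor, so this end of the molecule tolerates a ring nitrogen with a modest loss. Nothing shown explains this rise.

Open, on these data alone, is how a plain phenyl or a cyclohexyl would fare on that nitrogen. Also open, as far as these compounds go, is whether this swap would shift the fluoro compound 3 by a similar step.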